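The compounds below may be only part of what the source reports. "The series", "measured", "known", "first", "only" and "open" are said of these compounds alone.

Working notes on the series.

Compound 1 `CC(C)Cc1cc2oc(=O)n(CCC(=O)O)c2cc1Cl` is the reference point here. In a physicochemical assay for lipophilicity, read by HPLC, at pH 7.4 (a lower number here means a more polar compound, a higher number a more lipophilic compound), compound 1 gives 3.03, the highest of the three numbers measured. Its nearest neighbour is compound 2 `C[C@@H](Oc1cc2sc(=O)n(CCC(=O)O)c2cc1Cl)c1ccccn1`, which in this assay gives 1.81, a number beyond the scatter below compound 1. Furthest away is compound 3 `C[C@@H](Oc1cc2c(cc1Cl)N(CCC(=O)O)C(=O)CO2)c1ccccn1`, which in this assay gives 1.56, also beyond the scatter below compound 1. No pair among these three differs in one place only, so the gaps between them are simply recorded, not assigned to any single change.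

Going by the values given here, compound 4 `CCOc1cc2oc(=O)n(CCC(=O)O)c2cc1Cl` is the one unmeasured compound. It differs from compound 1 at a single position: ethoxy in place of isobutyl on an aromatic carbon. The ethoxy group brings in one hydrogen-bond acceptor where the isobutyl group had none, and it is one heavy atom smaller.

For compound 4 in this assay, the step of a number 1.43 log units lower from compound 1 to compound 4 (beyond the scatter) is expected to be a drop well beyond the scatter. The estimate for compound 4 in this assay is 1.6, with a range from 1.2 to 2.1.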

Compound 4, distribution coefficient: 1.49
Estimate against measurement, compound 4: 0.11 log units above; measured number inside the range.
By their numbers in this assay, from the lowest: compounds 4, 3 and 2 (each within the scatter of the next, the first and the last beyond it); then compound 1.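

Ethoxy in place of isobutyl on this aromatic carbon, ortho to a chloro group, gives in this assay a number 1.54 log units lower from compound 1 to compound 4 (beyond the scatter). Going by these compounds alone, this is the first gap that can be assigned to a single change, since the rest of the structure stays the same between the two compounds. The step is large, so the number in this assay depends strongly on the group at this position, but no measurement shown here accounts for its size.

The compounds shown do not separate the ether oxygen of ethoxy from the shorter chain, a question that a propyl group on the same carbon would address. As far as these compounds go, whether the same swap gives a step of similar size on another core, and how an amine at this position would read, also stay open.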